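Trimming an isopropyl amide to propanoyl on a shared core

This account rests on a few compounds, and the source may have more. Where it says the series, first, only, none or still open, it means among the compounds named here.

Of the compounds shown here, three built on one shared core have been measured in a functional assay on SGC-7901 cells (Homo sapiens) for inhibition, read by MTT assay, with a stated time of 72 h; a higher number here means a weaker inhibitor, a lower number a stronger inhibitor. Compound 1 `O=C1Nc2ccccc2/C1=C\C(=O)c1cc(F)cc(F)c1` carries two fluorines on its aryl ketone and in this assay compound 1 gives 17600 nM. Compound 2 `CC(=O)Nc1cccc(C(=O)/C=C2/C(=O)Nc3ccccc32)c1` replaces those fluorines with an acetylamino group, and compound 2 gives 14100 nM. Compound 3 `CC(C)C(=O)Nc1cccc(C(=O)/C=C2/C(=O)Nc3ccccc32)c1` enlarges that amide, and compound 3 gives 8600 nM, the lowest of the three numbers; its nearest neighbour is compound 2, within the scatter, while compound 1 lies beyond it.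

Compound 4 `CCC(=O)Nc1cccc(C(=O)/C=C2/C(=O)Nc3ccccc32)c1` differs from compound 3 by hydrogen in place of methyl on a saturated chain carbon bound to a carbonyl carbon and a saturated chain carbon, so the isopropylcarbonyl becomes a propanoyl group. Among the measured compounds shown here, the only step that bears on this is a 1.6-fold lower number from compound 2 to compound 3 (0.21 log units; within the scatter), where the amide grew from methyl to isopropyl and the number moved only within the scatter. Ethyl sits between those two sizes, so no step beyond the scatter is expected, and the number of compound 4 is expected to land between those of compound 2 and compound 3.

Compound 4 is therefore estimated at 10500 nM, with a range from 5500 nM to 20000 nM, a step of a 1.2-fold higher number from compound 3 to compound 4 (0.09 log units; within the scatter).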

Compound 4, half-maximal inhibitory concentration: 11500 nM
For compound 4 the middle estimate is 1.1-fold (0.04 log units) below the measured one, within the range that was stated.
By their numbers in this assay, from the lowest: compounds 3, 4, 2 and 1 (each within the scatter of the next, the first and the last beyond it).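

In this assay, taking one methyl off the isopropyl group gives a 1.3-fold higher number from compound 3 to compound 4 (0.13 log units; within the scatter) and putting one methyl on the acetyl group gives a 1.2-fold lower number from compound 2 to compound 4 (0.09 log units; within the scatter), so both moves to the ethyl group of the propanoyl amide stay inside the usual noise of the measurement. Before compound 4 there was one step on this amide, and with the middle size now filled in, compounds 2, 3 and 4 show that methyl, ethyl and isopropyl on this carbonyl carbon cannot be told apart in this assay, which means these three compounds give no trend with chain size to read. No separate measurement is available to explain this flat result.

From the compounds shown here alone, the three compounds cover only a narrow range of small saturated groups, so it remains open whether a longer chain such as butyl, a ring such as phenyl, or a group carrying an amine or a carboxylic acid at this carbonyl carbon would move the number beyond the scatter. It is also open whether the amide itself is needed, since no compound shown differs from these three by that one change alone.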